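Piperidine for piperazine on the anilide ring: stability outlook

The source may report more compounds than this note shows. Statements on the series, on what has been measured and on what is new or still open speak of the compounds shown alone.

Measured so far in an in vitro ADME assay on microsomes from liver (Homo sapiens) for metabolic stability, using NADPH, with a stated time of 10 min, tested at 0.5 uM; a higher number here means that the compound lasts longer, a lower number that the compound disappears faster:
Compound 1 `COc1ccc(Nc2ncc3ccc(-c4ccccc4OC)n3n2)cc1` gives 0.117 h.
Compound 2 `COc1ccccc1-c1ccc2cnc(Nc3ccc(N4CCN(C[C@H](C)O)CC4)cc3)nn12` gives > 0.666 h, which is a limit of the assay and not a number.
Compound 3 `COc1ccccc1-c1ccc2cnc(Nc3cccc(N4CCN(C[C@H](C)O)CC4)c3)nn12` gives 0.533 h.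

Compound 2 therefore stands at the top of the measured set, but only as a limit, (the limit of > 0.666 h in this assay, at which 1 of the 3 values shown sits). For the measured compounds named here, the one single-point step measured so far, an at least 5.6-fold higher number from compound 1 to compound 2 (0.75 log units; beyond the scatter), is at least modest and runs upward, though its true size is unknown for the same reason. Compound 3, which carries the same piperazine group on a different position of the same ring, sits below the limit but close to it.

Compound 4 `COc1ccccc1-c1ccc2cnc(Nc3ccc(C4CCN(C[C@H](C)O)CC4)cc3)nn12` differs from compound 2 by 1-(2-hydroxypropyl)piperidin-4-yl in place of 4-(2-hydroxypropyl)piperazin-1-yl on an aromatic carbon. Going by the values given here, no measured step swaps a ring nitrogen for a ring carbon, so the step cannot be anchored directly; the nearest evidence is the upward step from compound 1 to compound 2, which shows that the hydroxypropyl-bearing six-membered ring is compatible with a long half-life. For compound 4 in this assay the expectation is a change of about an at least 1.1-fold lower number from compound 2 to compound 4 (0.04 log units; that floor lies within the scatter) from compound 2, that is, within the scatter. Compound 4 is estimated at 0.6 h, between 0.3 h and 1.2 h, with a fair chance that only a limit is reported.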

Compound 4, half-life: > 0.666 h
Compound 4: no number, only a limit; the forecaster's own chance of this, stated with the estimate: 45%; at least 1.1-fold (0.04 log units) between middle value and limit.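

In this assay compound 4 gives > 0.666 h, which is a limit of the assay and not a number. The step between compound 2 and compound 4 cannot be read, because both compounds sit at the same limit: the limit of > 0.666 h in this assay, at which 2 of the 4 values shown sit.

What is new is that the piperazine ring is not required to reach this limit at this position: with one hetero atom in the ring instead of 2, 1-(2-hydroxypropyl)piperidin-4-yl in place of methoxy still gives an at least 5.6-fold higher number from compound 1 to compound 4 (0.75 log units; beyond the scatter).

Which of the two rings gives the longer half-life remains open, and answering that would need a read-out that yields numbers for both compound 2 and compound 4 rather than limits. Also open, as far as these compounds go, is what share of the step from the methoxy compound belongs to the 2-hydroxypropyl chain and what share to the ring itself, a question that a piperidine with a methyl group or an acetyl group on its nitrogen in place of that chain would address.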